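Swapping a Small Ether for a Larger Chlorophenoxy Ether

This account rests on a few compounds, and the source may have more. Where it says the series, first, only, none or still open, it means among the compounds named here.

Three nitrofuran amides have been tested in an ADME assay on Vero cells (Chlorocebus sabaeus) for cytotoxicity, read by MTT assay, with a stated time of 48 h; a higher number here means that more compound is tolerated, a lower number that less compound is tolerated. Compound 1 `O=C(Nc1ccccc1)c1ccc([N+](=O)[O-])o1` gives 6700 nM. Compound 2 `CC(C)(NC(=O)c1ccc([N+](=O)[O-])o1)c1ccc(OC(F)(F)F)cc1` gives 70000 nM. Compound 3 `O=C(NCc1ccc(-c2ccc(Cl)cc2)cc1)c1ccc([N+](=O)[O-])o1` gives 4400 nM. On these three numbers compound 2 stands highest: the value of compound 1 lies below it by a gap beyond the usual scatter, and the value of compound 3 lies further below still, also beyond the scatter. Among the measured compounds, then, compound 2 is the one the cells tolerate best.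

Compound 4 `CC(C)(NC(=O)c1ccc([N+](=O)[O-])o1)c1ccc(COc2ccc(Cl)cc2)cc1` has not yet been measured in this assay. It differs from compound 2 in one place: (4-chlorophenoxy)methyl in place of trifluoromethoxy on an aromatic carbon. For the measured compounds named here, no measured pair isolates a change of this kind, so the direction can only be read from the three compounds at hand. Going by the values given here, compound 3, the only other compound carrying a chlorine on a second aromatic ring, gives 4400 nM, the lowest value of the set, and on that basis the larger group is expected to lower the number. The expected step is a 4.7-fold lower number from compound 2 to compound 4 (0.67 log units; beyond the scatter), downward and beyond the scatter. Compound 4 is therefore estimated at 15000 nM, within a range from 5000 nM to 50000 nM.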

Compound 4, half-maximal cytotoxic concentration: 120000 nM
For compound 4 the middle estimate is 8.0-fold (0.90 log units) below the measured one; measured number outside the range, above it.
By their numbers in this assay, from the lowest: compounds 3 and 1 (each within the scatter of the next); then compounds 2 and 4 (each within the scatter of the next).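

In this assay the swap of trifluoromethoxy for (4-chlorophenoxy)methyl gives a 1.7-fold higher number from compound 2 to compound 4 (0.23 log units; within the scatter) and so leaves the two compounds indistinguishable, even though the new group is clearly the larger one, with more heavy atoms and a six-membered aromatic ring of its own. For the compounds shown here, this pair is the first in the set to differ in only one place, and it shows that, on this aromatic carbon para to a large group, a much bulkier group can take the place of a small ether with no change in cell tolerance that stands clear of the scatter. No measurement at hand explains why the tolerance holds across this swap.

This is a single change at a single position, so it cannot yet be said whether the chlorine on the added ring plays any part, and a plain phenoxymethyl group or a bromine in its place would address that. As far as these compounds go, it also remains open whether groups of a different kind at this position, such as an amine, a carboxylic acid or a longer alkyl chain, would stay within the scatter as well.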